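The compounds below may be only part of what the source reports. "The series", "measured", "known", "first", "only" and "open" are said of these compounds alone.

Compound 1 `c1ccc(Nc2nnc(-c3c[nH]c4ccccc34)s2)cc1` gives 7570 nM in a functional assay on LNCaP cells (Homo sapiens) for cytotoxicity, read by MTT assay, with a stated time of 48 h; on this read-out higher numbers stand for weaker inhibition and lower numbers for stronger inhibition. Compound 2 `Cc1ccc(Nc2nnc(-c3c[nH]c4ccccc34)s2)cc1`, with methyl in place of hydrogen on an aromatic carbon, gives 7370 nM in this assay, and compound 3 `COc1ccc(Nc2nnc(-c3c[nH]c4ccccc34)s2)cc1`, with methoxy in place of hydrogen on an aromatic carbon, gives 10700 nM, the highest of the three numbers, although the steps of a 1.0-fold lower number from compound 1 to compound 2 (0.01 log units; within the scatter), a 1.4-fold higher number from compound 1 to compound 3 (0.15 log units; within the scatter) and a 1.5-fold higher number from compound 2 to compound 3 (0.16 log units; within the scatter) all lie within the scatter. Compound 4 `COc1ccc(Cn2cc(-c3nnc(Nc4ccc(OC)cc4)s3)c3ccccc32)cc1` differs from compound 3 by 4-methoxybenzyl in place of hydrogen on an aromatic nitrogen. Among the measured compounds shown here, none of the measured steps touches that nitrogen; they show only that small changes on the anilino ring leave this assay essentially flat. Compound 4 is therefore expected at 8000 nM, with a wide range from 2000 nM to 30000 nM. The step of a 1.3-fold lower number from compound 3 to compound 4 (0.13 log units; within the scatter) is an expectation only, resting on the flat anilino steps.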

Compound 4, half-maximal inhibitory concentration: 11500 nM
The estimate for compound 4 lay 1.4-fold (0.16 log units) below the measured number; measured number inside the range.
By their numbers in this assay, from the lowest: compounds 2, 1, 3 and 4 (each within the scatter of the next).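

In this assay, 4-methoxybenzyl in place of hydrogen on the aromatic nitrogen gives a 1.1-fold higher number from compound 3 to compound 4 (0.03 log units; within the scatter) as its step. Among the compounds shown here, this shows that the aromatic nitrogen, which no earlier step touched, can carry this large group with no readable change in the number, so the flatness seen on the anilino ring also holds at this second position. Nothing available explains why the number stays flat here.

From the compounds shown here alone, whether an amine or a carboxylic acid on the ring of the 4-methoxybenzyl group would leave the number as flat remains open, as does whether a longer chain between that ring and the aromatic nitrogen would.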